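A few compounds are considered here, and "the series" means these few. Any claim that something is new, unique, unknown or untested is made for them only; others in the source may bear on it.

Values measured so far in a functional assay (trachea) with Cavia porcellus as the target (on this read-out higher numbers stand for weaker inhibition and lower numbers for stronger inhibition), are these:

Compound 1 `CC(=O)OCCn1nc(-c2cccnc2)c2ccccc2c1=O` gives 9770 nM
Compound 2 `O=C(O)Cn1nc(-c2cccnc2)c2ccccc2c1=O` gives > 100000 nM (a limit)

As far as these compounds go, for compound 2 the reading > 100000 nM is only a limit of the assay and not a number, so its true position is unknown.

Compound 3 `O=C(O)c1ccc(Cn2nc(-c3cccnc3)c3ccccc3c2=O)cc1` differs from compound 2 in one place, on a saturated chain carbon bound to an aromatic nitrogen, where 4-carboxyphenyl takes the place of carboxy 4-carboxyphenyl in place of carboxy on a saturated chain carbon bound to an aromatic nitrogen and a carboxy group therefore remains.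

Within the data shown here, only one measured step bears on this change, and it is large. Compound 3 is expected to stay weak in this assay because an at least 10-fold higher number from compound 1 to compound 2 (1.01 log units; beyond the scatter) ends on a carboxy group, which compound 3 keeps.

A modest move toward stronger inhibition is expected, estimated as an at least 2.0-fold lower number from compound 2 to compound 3 (0.30 log units; that floor lies within the scatter) and resting on little evidence.

For compound 3 the estimated value is 50000 nM (range 12000 nM to 100000 nM), and the assay may again report only a limit.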

Compound 3, half-maximal inhibitory concentration: 17000 nM
Beside the measured number, compound 3's estimate is 2.9-fold (0.47 log units) above it; the measured number falls inside the stated range.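

In this assay, 4-carboxyphenyl in place of carboxy on a saturated chain carbon bound to an aromatic nitrogen gives an at least 5.8-fold lower number from compound 2 to compound 3 (0.76 log units; beyond the scatter), so a carboxy group at this position does not by itself fix a compound at the weak end. That step is only a floor, since the reading for compound 2 is a limit of the assay and not a number: the limit of > 100000 nM in this assay, at which 1 of the 3 values shown sits.

Compound 3 keeps its carboxy group, yet the change from acetoxymethyl gives a 1.7-fold higher number from compound 1 to compound 3 (0.24 log units; within the scatter), which places the two level on this read-out.

As far as these compounds go, what remains open is whether the added aromatic ring alone accounts for the difference, or the way it carries the carboxy group. A plain phenyl group, or a longer chain ending in a carboxylic acid, at this position would help separate those two readings.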